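The source may report more compounds than this note shows. Statements on the series, on what has been measured and on what is new or still open speak of the compounds shown alone.

Measured in a functional assay for inhibition, with Rattus norvegicus as the target; on this read-out lower numbers stand for stronger inhibition and higher numbers for weaker inhibition:
- Compound 1 `CC(/N=c1\c(O)c(O)\c1=N/c1ccc(S(N)(=O)=O)cc1)C(C)(C)C`: > 30000 nM (a limit of the assay, not a number)
- Compound 2 `CC(/N=c1\c(O)c(O)\c1=N/c1ccc(C#N)cc1)C(C)(C)C`: 520 nM
- Compound 3 `CC(/N=c1\c(O)c(O)\c1=N/c1ccc(-n2ccnc2)cc1)C(C)(C)C`: > 30000 nM (a limit of the assay, not a number)

Within the data shown here, compound 2 holds the only true number in this small set, and the other two compounds sit at a limit. Its steps to both of them are large and beyond the scatter: an at least 57-fold lower number from compound 1 to compound 2 (1.76 log units; beyond the scatter), and an at least 57-fold higher number from compound 2 to compound 3 (1.76 log units; beyond the scatter). Both steps swap the group on an aromatic carbon, so the read-out clearly can move far when that group changes.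

Compound 4 `CC(C)C(C)/N=c1\c(O)c(O)\c1=N/c1ccc(C#N)cc1` keeps the cyano group of compound 2 and alters the chain instead: hydrogen in place of methyl on a saturated chain carbon bound to three saturated chain carbons. This is hydrogen in place of methyl on a saturated chain carbon bound to three saturated chain carbons, which turns tert-butyl into isopropyl. Among the measured compounds shown here, no measured step touches this chain, so the large steps above give only a loose guide to what this change will do.

The starting point for the expectation is therefore compound 2 at 520 nM. A small step is expected, leaning slightly towards a higher number and possibly not beyond the scatter: a 1.5-fold higher number from compound 2 to compound 4 (0.19 log units; within the scatter). The estimated value for compound 4 is 800 nM, with an expected range of 250 nM to 3000 nM.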

Compound 4, half-maximal inhibitory concentration: 1900 nM
Compound 4: middle estimate off by 2.4-fold (0.38 log units), on the low side; the range from low to high includes it.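

In this assay, the chain matters as well as the group on the aromatic carbon: hydrogen in place of methyl on a saturated chain carbon bound to three saturated chain carbons gives a 3.7-fold higher number from compound 2 to compound 4 (0.56 log units; beyond the scatter). Turning tert-butyl into isopropyl removes a single carbon, yet it gives clearly weaker inhibition, although the step is only modest. Compound 4 still gives a true number, so this step can be read in full, which is not the case for a step that ends at a limit: the limit of > 30000 nM in this assay, at which 2 of the 4 values shown sit.

One pair of compounds cannot show whether inhibition keeps weakening as the chain gets smaller or whether it recovers with a different group, such as an ethyl group, a longer chain, a cyclohexyl ring or a chain carrying an amine. From the compounds shown here alone, it also remains open whether the change from tert-butyl to isopropyl would have a similar effect with something other than the cyano group on the aromatic carbon, such as a carboxylic acid.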